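Tetrahydroisoquinoline Amide Sulfamate Awaiting Its Measurement

The source may report more compounds than this note shows. Statements on the series, on what has been measured and on what is new or still open speak of the compounds shown alone.

Compound 1 `CCN(Cc1ccc(F)cc1)c1cccc(C(=O)N2CCc3ccc(OS(N)(=O)=O)cc3C2)c1`: 10.9%
Compound 2 `CN(C)CCN(CCN(C)C)c1cccc(C(=O)N2CCc3ccc(OS(N)(=O)=O)cc3C2)c1`: 0%
Compound 3 `NS(=O)(=O)Oc1ccc2c(c1)CN(C(=O)c1cccc(N3CCc4ccccc4C3)c1)CC2`: not yet measured

In an assay on HEK293 cells for inhibition of Steryl-sulfatase (Homo sapiens), tested at 0.1 uM (a lower number here means a weaker effect, a higher number a stronger effect of the compound at the concentration tested), compound 2 gives 0%, the lowest of the two numbers; compound 1 gives 10.9%. Among the compounds with values here, the one measured step, a number 10.9 percentage points lower from compound 1 to compound 2 (beyond the scatter), is modest. Compound 3 differs from compound 2 by 1,2,3,4-tetrahydroisoquinolin-2-yl in place of bis(2-(dimethylamino)ethyl)amino on an aromatic carbon. Within the data shown here, no measured step covers this exact change, but compound 1, with ethyl(4-fluorobenzyl)amino, stood higher than compound 2, so a similar modest rise is expected, a number 10 percentage points higher from compound 2 to compound 3 (within the scatter). Compound 3 is therefore estimated at 10%, within 0% to 25%.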

Compound 3, a percentage reported as inhibition, at one concentration (the size of the read-out at that concentration, not a potency): 24.1%
Beside the measured number, compound 3's estimate is 14.1 percentage points below it; the range from low to high includes it.
By their numbers in this assay, from the lowest: compound 2; then compound 1; then compound 3.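

In this assay, compound 3 is the only one of the three whose group at this position holds its nitrogen in a ring, and 1,2,3,4-tetrahydroisoquinolin-2-yl in place of bis(2-(dimethylamino)ethyl)amino gives a number 24.1 percentage points higher from compound 2 to compound 3 (beyond the scatter). It also outdoes the open-chain ethyl(4-fluorobenzyl)amino, with a number 13.2 percentage points higher from compound 1 to compound 3 (beyond the scatter), making compound 3 the highest of the three, though both steps remain modest. No evidence is available on what lies behind this difference.

On these data alone, it remains open whether a piperidine or a morpholine at this position would reach the same level. Also open, as far as these compounds go, is whether the six-membered aromatic ring of the entering group contributes to the rise.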